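The compounds below may be only part of what the source reports. "The series", "measured", "known", "first", "only" and "open" are said of these compounds alone.

Measured so far in a physicochemical assay for lipophilicity, read by HPLC, with a stated time of 90 min, tested at 100 uM; a higher number here means a more lipophilic compound, a lower number a more polar compound:
compound 1 `O=C(Nc1ccc(C(F)(F)F)cc1)NC1CCN(C(=O)C2CCCOC2)CC1` gives 3.41
compound 2 `O=C(Nc1ccc(C(F)(F)F)cc1)NC1CCN(C(=O)[C@@H]2CCOC2)CC1` gives 3.27
compound 3 `O=C(Nc1ccc(C(F)(F)F)c(F)c1)NC1CCN(C(=O)C2CCCOC2)CC1` gives 3.84

Compound 4 `O=C(Nc1ccc(C(F)(F)F)c(F)c1)NC1CCN(C(=O)[C@@H]2CCOC2)CC1` has not yet been measured. It differs from compound 3 by oxolan-3-yl in place of oxan-3-yl on a carbonyl carbon. The same change, (oxolan-3-yl in place of oxan-3-yl on a carbonyl carbon), separates compound 1 from compound 2, where it gave a number 0.14 log units lower from compound 1 to compound 2 (within the scatter). The two cores differ by fluoro in place of hydrogen on an aromatic carbon, a change that gave a number 0.43 log units higher from compound 1 to compound 3 (beyond the scatter) and leaves compound 3 with the highest number of the three. The place of the ring swap is the same word for word in both pairs, so the step is taken as the same change rather than merely one of the same kind. For compound 4 the expected step is a number 0.14 log units lower from compound 3 to compound 4 (within the scatter), resting on a number 0.14 log units lower from compound 1 to compound 2 (within the scatter). Compound 4 is therefore estimated at 3.7, with a likely range from 3.45 to 3.95.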

Compound 4, partition coefficient: 3.41
The estimate for compound 4 lay 0.29 log units above the measured number; the measured number lies below the stated range.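

In this assay, oxolan-3-yl in place of oxan-3-yl gave a number 0.43 log units lower from compound 3 to compound 4 (beyond the scatter) on the fluoro-bearing core, while the same change gave a number 0.14 log units lower from compound 1 to compound 2 (within the scatter) on the core without fluoro, so its direction held but only the first step lies beyond the scatter. Fluoro in place of hydrogen likewise gave a number 0.14 log units higher from compound 2 to compound 4 (within the scatter) with oxolan-3-yl present, against a number 0.43 log units higher from compound 1 to compound 3 (beyond the scatter) with oxan-3-yl present. Two pairs cannot fix a size for the ring change on further cores, and nothing available explains why the steps differ.

The compounds shown leave open how an open-chain methoxyethyl group or a carboxylic acid would behave on the carbonyl carbon. They also leave open whether chloro in place of fluoro would alter the ring change in the same way.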